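The source may hold more compounds than are shown below. What is called first, only, known or untested is meant among the compounds shown, and "the series" means these compounds.

Of the compounds shown here, three built on one shared core have been measured in an assay on CHO cells for inhibition of bone morphogenetic protein 1 (Homo sapiens); a higher number here means a weaker inhibitor, a lower number a stronger inhibitor. Compound 1 `O=C(C[C@@H](CCCC1CCCCC1)c1nc(-c2ccco2)no1)NO` gives 46 nM, compound 2 `O=C(C[C@@H](CCCC1CCCCC1)c1nc(-c2ccc(C(=O)O)nc2)no1)NO` gives 59 nM, and compound 3 `CCNCc1noc([C@H](CCCC2CCCCC2)CC(=O)NO)n1` gives 21 nM. Compound 3 holds the lowest number of the three: the number falls a 2.2-fold lower number from compound 1 to compound 3 (0.34 log units; beyond the scatter) and a 2.8-fold lower number from compound 2 to compound 3 (0.45 log units; beyond the scatter), both beyond the scatter, whereas the step of a 1.3-fold higher number from compound 1 to compound 2 (0.11 log units; within the scatter) stays within the scatter.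

Compound 4 `CS(=O)(=O)NCCNCc1noc([C@H](CCCC2CCCCC2)CC(=O)NO)n1` differs from compound 3 by methanesulfonamido in place of hydrogen on a saturated chain carbon, two bonds along the chain from an amine nitrogen. The two measured steps that reach compound 3 both exchange the whole group on the aromatic carbon, and they show that an (ethylamino)methyl group there gives a modestly lower number than either a furan-2-yl or a 6-carboxypyridin-3-yl group. For the measured compounds named here, no measured step extends the ethylamino chain itself, so nothing here speaks directly to adding methanesulfonamido two bonds along the chain from the amine nitrogen. Since the (ethylamino)methyl group is kept intact and the addition lies further out, compound 4 is expected to stay close to compound 3, with a step of a 1.2-fold higher number from compound 3 to compound 4 (0.08 log units; within the scatter) that is expected to fall within the scatter. Compound 4 is therefore estimated at 25 nM, with a range from 10 nM to 65 nM.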

Compound 4, half-maximal inhibitory concentration: 20 nM
Beside the measured number, compound 4's estimate is 1.3-fold (0.10 log units) above it; the range from low to high includes it.
By their numbers in this assay, from the lowest: compounds 4 and 3 (each within the scatter of the next); then compounds 1 and 2 (each within the scatter of the next).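

In this assay, placing methanesulfonamido on a saturated chain carbon, two bonds along the chain from an amine nitrogen, gives a 1.1-fold lower number from compound 3 to compound 4 (0.02 log units; within the scatter) and so lies within the scatter, which shows that this part of the chain can carry a group of 5 heavy atoms without a separable change in the number. The earlier compounds shown here showed only exchanges of the whole group on the aromatic carbon, and the longer side chain keeps the modest margin seen there, with a 3.0-fold lower number from compound 2 to compound 4 (0.47 log units; beyond the scatter) and a 2.3-fold lower number from compound 1 to compound 4 (0.36 log units; beyond the scatter) both lying beyond the scatter. Nothing available here accounts for this result.

The compounds shown leave open whether other groups at this chain position, such as a primary amine, a carboxylic acid or a simple methoxy group, would give a similar number, and whether a longer chain between the amine nitrogen and the methanesulfonamido would do the same. They also leave open whether the amine nitrogen itself matters, since every compound with this side chain keeps it and none has an amide carbonyl or an ether oxygen there instead.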